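A few compounds are considered here, and "the series" means these few. Any claim that something is new, unique, unknown or untested is made for them only; others in the source may bear on it.

Series notes on the measured compounds, all read in a functional assay on PC-3 cells (Homo sapiens) for cytotoxicity, read by MTT assay, with a stated time of 72 h; on this read-out lower numbers stand for higher toxicity in this test and higher numbers for lower toxicity in this test:

Compound 1 `C[Se]/C(=N\C(=O)c1cc2ccccc2s1)NC(=O)c1cc2ccccc2s1` gives 94000 nM.
Compound 2 `CS/C(=N\C(=O)c1ccno1)NC(=O)c1ccno1` gives > 100000 nM, which is a limit of the assay and not a number.
Compound 3 `O=C(/N=C(/NC(=O)c1ccco1)[Se]Cc1ccccc1)c1ccco1` gives 84800 nM.

Compound 1 holds the highest of the two numbers in hand, and compound 3 sits within the usual scatter of it, so the two are not separated by this read-out. Compound 2 contributes only a limit, the one described as the limit of > 100000 nM in this assay, at which 1 of the 3 values shown sits. Among the measured compounds shown here, no two measured compounds differ in a single place, so no measured step can be drawn from them.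

Compound 4 `O=C(/N=C(/NC(=O)c1cc2ccccc2s1)[Se]Cc1ccccc1)c1cc2ccccc2s1` is not yet measured. It differs from compound 1 by phenyl in place of hydrogen on a saturated chain carbon bound to a selenium atom; cut one bond further out, methyl becomes benzyl. Compound 3 carries a benzyl on selenium with another core and gives 84800 nM, close to the number of compound 1. On that basis the step expected in this assay is a 1.1-fold lower number from compound 1 to compound 4 (0.04 log units; within the scatter), with no change beyond the scatter in either direction. Compound 4 is estimated at 85000 nM, with a range from 40000 nM to 180000 nM. A limit-only result cannot be excluded.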

Compound 4, concentration lethal to 50% of the cells: 86300 nM
For compound 4 the middle estimate is 1.0-fold (0.01 log units) below the measured one; low and high end bracket the measured number.
By their numbers in this assay, from the lowest: compounds 3, 4 and 1 (each within the scatter of the next). At a limit, above all of these: compound 2.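

In this assay the series now holds its first pair of compounds differing in one place, and a 1.1-fold lower number from compound 1 to compound 4 (0.04 log units; within the scatter) is the direct reading for that pair on the core of compound 1. The change is phenyl in place of hydrogen on a saturated chain carbon bound to a selenium atom, or methyl to benzyl when cut one bond further out, so this place has now been read directly rather than inferred from a compound with another core. One six-membered aromatic ring of carbon only enters here with no change beyond the scatter, which holds for this single pair and this single core and makes no claim about the place in general.

Still open, from the compounds shown here alone, is how an amine, a carboxylic acid or a longer chain in place of the benzyl on selenium would read at this place, and whether methyl to benzyl reads the same on any other core. Among the compounds shown here, compound 2 gives a limit of the assay and not a number, so it offers no step to read: the limit of > 100000 nM in this assay, at which 1 of the 4 values shown sits.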